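The source may report more compounds than this note shows. Statements on the series, on what has been measured and on what is new or still open speak of the compounds shown alone.

Compound 1 `COc1cccc(Sc2c[nH]c3ccc(Cl)cc23)c1` and compound 2 `COc1ccc(Sc2c[nH]c3ccc(Cl)cc23)cc1` are built from the same atoms, joined differently; the difference between the two cores is not broken down here. In an assay on isolated protein for inhibition of Indoleamine 2,3-dioxygenase 1 (Homo sapiens), read by HPLC, with a stated time of 60 min, in the presence of a further agent that is not named here (a lower number here means a stronger inhibitor, a higher number a weaker inhibitor), compound 1 gives 21000 nM, and compound 2 gives 16000 nM, two values that lie within the usual scatter of each other. Compound 3 `COc1ccc(Sc2c[nH]c3ccc(Cl)cc23)c(OC)c1` carries one further methoxy relative to compound 2: methoxy in place of hydrogen on an aromatic carbon. In this assay compound 3 reaches only a limit of the assay, > 50000 nM. The resulting step, an at least 3.1-fold higher number from compound 2 to compound 3 (0.49 log units; beyond the scatter), is a weakening, and its size rests on (the limit of > 50000 nM in this assay, at which 1 of the 3 values shown sits). Compound 4 `COc1cc(OC)cc(Sc2c[nH]c3ccc(Cl)cc23)c1` has not yet been measured; it arises from compound 1 by the same kind of change, (methoxy in place of hydrogen on an aromatic carbon), the entering methoxy now sitting meta to a large group instead of ortho to a large group, while meta to a methoxy group in both cases. The step from compound 2 to compound 3, an at least 3.1-fold higher number from compound 2 to compound 3 (0.49 log units; beyond the scatter), guides the expectation. Compound 4 is therefore expected to show a 2.4-fold higher number from compound 1 to compound 4 (0.38 log units; beyond the scatter). Compound 4 is estimated at 50000 nM, within 20000 nM to 150000 nM, quite possibly reported only as a limit.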

Compound 4, half-maximal inhibitory concentration: 7000 nM
For compound 4 the middle estimate is 7.1-fold (0.85 log units) above the measured one; the measured number lies below the stated range.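

In this assay the entering methoxy gives a 3.0-fold lower number from compound 1 to compound 4 (0.48 log units; beyond the scatter), so the direction of this change does not carry over from one core to the other in this series: the same change on two cores in this assay, an at least 3.1-fold higher number (0.49 log units; beyond the scatter) from compound 2 to compound 3 and a 3.0-fold lower number (0.48 log units; beyond the scatter) from compound 1 to compound 4, at least 9.3-fold (0.97 log units) apart, beyond the scatter of two such steps

Compound 3 is held only at a limit of the assay, and the gap between the two steps is a minimum that rests on it: the limit of > 50000 nM in this assay, at which 1 of the 4 values shown sits.

Among the compounds shown here, the two steps do not show why they part, since the entering methoxy in compound 4 also differs in place from the one in compound 3, and two pairs cannot separate that difference from the core itself or say how the change would behave on any further core.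

The compounds shown leave open how an amine, a carboxylic acid or a longer chain would read at the place taken by the entering methoxy in compound 4. They also leave open whether the lower number of compound 4 would hold if the chlorine of the shared core were replaced by hydrogen.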